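Replacing a Chlorophenyl with a Methylphenyl on the Thiourea Nitrogen

The compounds below may be only part of what the source reports. "The series", "measured", "known", "first", "only" and "open" are said of these compounds alone.

Measured compounds:
compound 1, `COc1ccc(C)cc1NC(=S)N/N=C/c1ccc2ccccc2n1`: reported only as a limit, > 100000 nM
compound 2, `S=C(N/N=C/c1ccc2ccccc2n1)Nc1ccc(Br)cc1`: 27500 nM
compound 3, `S=C(N/N=C/c1ccc2ccccc2n1)Nc1cccc(Cl)c1`: 28800 nM

In a functional assay on HL-60 cells (Homo sapiens) for antiproliferative activity, read by sulforhodamine B assay, with a stated time of 72 h (on this read-out higher numbers stand for weaker inhibition and lower numbers for stronger inhibition), compound 2 gives 27500 nM and compound 3 gives 28800 nM. For compound 1 the result is a limit of the assay, > 100000 nM, not a number. Compound 3 therefore stands highest of the two numbers, but the step of a 1.0-fold higher number from compound 2 to compound 3 (0.02 log units; within the scatter) lies within the scatter, so compound 2 and compound 3 cannot be placed in any order.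

Compound 4, `Cc1ccccc1NC(=S)N/N=C/c1ccc2ccccc2n1`, differs from compound 3 in one place: 2-methylphenyl in place of 3-chlorophenyl on an amide-type nitrogen. Among the measured compounds shown here, the only measured step, a 1.0-fold higher number from compound 2 to compound 3 (0.02 log units; within the scatter), exchanged one halogen-bearing phenyl for another on the same nitrogen and left the number where it was; it gives no guide for a methylphenyl. Compound 1, carrying yet another substituted phenyl on that nitrogen, sits at the limit of > 100000 nM in this assay, at which 1 of the 3 values shown sits, which shows that such a change can push the result out of range. The expectation for compound 4 is thus wide and leans toward a weaker result, with a 1.7-fold higher number from compound 3 to compound 4 (0.24 log units; within the scatter) expected. Compound 4 is estimated to give about 50000 nM, between 18000 nM and 150000 nM.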

Compound 4, half-maximal inhibitory concentration: 73200 nM
Compound 4: the middle estimate sits 1.5-fold (0.17 log units) below what was measured, and the stated range covers the measured number.
By their numbers in this assay, from the lowest: compounds 2 and 3 (each within the scatter of the next); then compound 4. At a limit, above all of these: compound 1.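

In this assay, among the compounds shown here, compound 4 is the first compound with a number clearly apart from the others on this amide-type nitrogen, with a 2.5-fold higher number from compound 3 to compound 4 (0.41 log units; beyond the scatter) and a 2.7-fold higher number from compound 2 to compound 4 (0.43 log units; beyond the scatter). The substituted phenyl at this position therefore does affect the read-out: the 4-bromophenyl and 3-chlorophenyl of compounds 2 and 3 gave values within the scatter of each other, whereas 2-methylphenyl gives a weaker result, though only by a modest step. Compound 1, which also carries a different substituted phenyl on this nitrogen, remains a limit of the assay and not a number: the limit of > 100000 nM in this assay, at which 1 of the 4 values shown sits.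

The change from 3-chlorophenyl to 2-methylphenyl alters both the substituent and where it sits on the phenyl, and the compounds shown cannot separate these two differences. On these data alone, it also remains open how the result would read with an amine or a carboxylic acid on the phenyl, or with a longer chain in place of the phenyl on this nitrogen.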